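This account rests on a few compounds, and the source may have more. Where it says the series, first, only, none or still open, it means among the compounds named here.

Of the compounds shown here, three built on one shared core have been tested in a functional assay on HL-60 cells (Homo sapiens) for cytotoxicity, read by MTT assay, with a stated time of 72 h; on this read-out lower numbers stand for stronger inhibition and higher numbers for weaker inhibition. Compound 1 `COc1ccc(C(=O)O[C@H]2CC(C)=C[C@H](OC(C)=O)[C@@]3(C)[C@@H](OC(C)=O)C[C@@](O)(C(C)C)[C@H]23)cc1` gives 11300 nM in this assay. Compound 2 `C/C=C(/C)C(=O)O[C@H]1CC(C)=C[C@@H](OC(=O)/C(C)=C\C)[C@@]2(C)CC[C@@](O)(C(C)C)[C@H]12` gives 2600 nM. Compound 3 `COc1ccc(C(=O)O[C@H]2CC(C)=C[C@H](O)[C@@]3(C)[C@@H](OC(C)=O)C[C@@](O)(C(C)C)[C@H]23)cc1` gives 23000 nM, the highest of the three numbers, so among these it is the weakest inhibitor; its nearest neighbour is compound 1, and compound 2 lies furthest from it. Among the compounds with values here, the only single change that has been measured is a 2.0-fold higher number from compound 1 to compound 3 (0.31 log units; beyond the scatter). Compound 4 `COc1ccc(C(=O)O[C@H]2CC(C)=C[C@@H](O)[C@@]3(C)[C@@H](OC(C)=O)C[C@@](O)(C(C)C)[C@H]23)cc1` differs from compound 3 in this way: the two compounds have the same atoms and bonds and differ only in configuration as drawn: 1 of 6 stereo elements differ; a stereocentre at a saturated ring carbon is drawn S in compound 3 and R in compound 4. Within the data shown here, none of the measured steps concerns a change in configuration alone, so the data give no guide to which direction such a change moves the number, or how far. The step expected is therefore no change at the digits printed from compound 3 to compound 4 (within the scatter), lying within the scatter, with a wide range to reflect the absence of any comparable measurement. Compound 4 is estimated at 23000 nM in this assay, and is expected to fall between 7000 nM and 75000 nM.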

Compound 4, half-maximal inhibitory concentration: 24000 nM
Beside the measured number, compound 4's estimate is 1.0-fold (0.02 log units) below it, within the range that was stated.
By their numbers in this assay, from the lowest: compound 2; then compound 1; then compounds 3 and 4 (each within the scatter of the next).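

Within the data shown here, until now the only measured step was a swap of acetyl for hydrogen, so nothing showed what configuration alone does on this core. This pair isolates that question, and the reading rests on one fact: the fact that compounds 3 and 4 differ only in the configuration as drawn. In this assay the result is a 1.0-fold higher number from compound 3 to compound 4 (0.02 log units; within the scatter) and so, for this pair, drawing this saturated ring carbon as S or as R makes no difference that can be told apart from the scatter of repeated measurements.

Going by these compounds, one pair gives no general rule, so it remains open whether the same change in configuration would also have no visible effect on a compound that keeps the acetyl, such as compound 1. Also open, on these data alone, is what an amine or a longer ester chain in place of the free hydroxyl would do to the number.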